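Moving the fluorine on a phenylsulfonyl group

This account rests on a few compounds, and the source may have more. Where it says the series, first, only, none or still open, it means among the compounds named here.

Compound 1: `COc1cccc(S(=O)(=O)c2ccccc2)c1Cc1c2c(n(CC(=O)O)c1C)CCNC2=O` — 4500 nM
Compound 2: `Cc1c(Cc2ccccc2S(=O)(=O)c2ccccc2F)c2c(n1CC(=O)O)CCNC2=O` — 3.6 nM

In a functional assay on CHO.K1 cells for antagonist activity at prostaglandin D2 receptor 2 (Homo sapiens), read by GTPgammaS binding, with a stated time of 1 h (a higher number here means a weaker inhibitor, a lower number a stronger inhibitor), compound 1 gives 4500 nM. In this assay compound 2 gives 3.6 nM, the lower of the two numbers, and the gap between compound 2 and compound 1 lies far beyond the scatter of repeated measurements, so compound 2 is the stronger inhibitor of the pair.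

Compound 3, `Cc1c(Cc2ccccc2S(=O)(=O)c2ccc(F)cc2)c2c(n1CC(=O)O)CCNC2=O`, has not yet been measured. It differs from compound 2 in a single place: 4-fluorophenyl in place of 2-fluorophenyl on a sulfonyl sulfur. The two compounds hold the same atoms, joined differently, and the shared core of compound 2 is kept unchanged.

Within the data shown here, no measured pair of this kind is available, so the size of the step can only be expected, not read off. The change is small in count and leaves every other part of compound 2 intact, so the step of a 2.2-fold higher number from compound 2 to compound 3 (0.35 log units; beyond the scatter) is expected to be modest, most likely a slight move toward a higher number, and it may well stay within the scatter. For compound 3 the estimate in this assay is 8 nM, with a range from 2 nM to 40 nM.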

Compound 3, half-maximal inhibitory concentration: 3.3 nM
Estimate against measurement, compound 3: 2.4-fold (0.38 log units) above; the range from low to high includes it.
By their numbers in this assay, from the lowest: compounds 3 and 2 (each within the scatter of the next); then compound 1.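

In this assay moving the fluorine from 2-fluorophenyl to 4-fluorophenyl on a sulfonyl sulfur amounts to a 1.1-fold lower number from compound 2 to compound 3 (0.04 log units; within the scatter) and so gives no measurable preference between these two placements. This is the first step shown that changes a single place while the shared core stays the same, and it indicates that, for this pair, the number does not depend on which of the two fluorophenyl groups sits on the sulfonyl sulfur. No measured evidence bears on why the two compounds read alike.

Still open, on these data alone, is whether the same holds for other groups on that ring, such as chlorine, trifluoromethyl or a nitrile in place of the fluorine, or for a methoxy group on the ring of the sulfonyl sulfur. Compound 1 differs from compound 2 and compound 3 in more than one place, so the compounds shown do not assign its much higher number to any single change, and what each of those changes contributes remains to be separated.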